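From nitro to amino on compound 2

The source may report more compounds than this note shows. Statements on the series, on what has been measured and on what is new or still open speak of the compounds shown alone.

Of the compounds shown here, three have been measured in an ADME assay on TZM cells (Homo sapiens) for cytotoxicity, read by XTT assay, with a stated time of 4 days (a lower number here means that less compound is tolerated, a higher number that more compound is tolerated), so far, and only one of them returned a true number. Compound 2 `CC(=O)/C=C/c1cc(C)c(Oc2cc(Nc3ccc(C#N)cc3)c([N+](=O)[O-])cc2[N+](=O)[O-])c(C)c1` gives 24400 nM as that single number. Compound 1 `CC(=O)/C=C/c1cc(C)c(Oc2ccc([N+](=O)[O-])c(Nc3ccc(C#N)cc3)n2)c(C)c1` shows > 46700 nM and this is a limit of the assay. Compound 3 `Cc1cc(/C=C/C#N)cc(C)c1Oc1cc(Nc2ccc(C#N)cc2)c([N+](=O)[O-])cc1[N+](=O)[O-]` shows > 43900 nM and this too is a limit of the assay.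

Compound 4 `CC(=O)/C=C/c1cc(C)c(Oc2cc(Nc3ccc(C#N)cc3)c(N)cc2[N+](=O)[O-])c(C)c1` has not yet been measured. It departs from compound 2 by one exchange, amino in place of nitro on an aromatic carbon with amino in place of nitro on an aromatic carbon, ortho to a (4-cyanophenyl)amino group and meta to a nitro group.

For the measured compounds named here, only one measured step bears on this, and it bears only indirectly. That step is an at least 1.7-fold higher number from compound 2 to compound 3 (0.25 log units; that floor lies within the scatter) and it lies on the chain, leaving both nitro groups in place. Its floor lies within the scatter, so it gives no ground to expect a large move for compound 4. Going by the values given here, no measurement yet covers the exchange of a nitro group itself.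

The estimated change, a 1.0-fold lower number from compound 2 to compound 4 (0.01 log units; within the scatter) in this assay is expected to stay within the scatter, with no firm direction. Compound 4 is expected at 24000 nM in this assay with 9000 nM to 55000 nM as the estimated range.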

Compound 4, half-maximal cytotoxic concentration: 5880 nM
The estimate for compound 4 lay 4.1-fold (0.61 log units) above the measured number; measured number below the stated range.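

In this assay, putting amino in place of nitro on the aromatic carbon ortho to a (4-cyanophenyl)amino group and meta to a nitro group gives a 4.1-fold lower number from compound 2 to compound 4 (0.62 log units; beyond the scatter). This is the only step shown that lies beyond the scatter and the only one that touches a nitro group on the ring, whereas the change on the chain, an at least 1.7-fold higher number from compound 2 to compound 3 (0.25 log units; that floor lies within the scatter), has a floor within the scatter. Nothing measured among the compounds shown accounts for this drop.

Going by these compounds, it remains open whether the lower number follows from the loss of the nitro group or the arrival of the amino group, and other groups on this carbon, such as an acetamide or a methoxy group, could separate the two. On these data alone, it is equally open whether the exchange would have a similar effect at the remaining nitro group or on the cyano-bearing chain, where compound 3 stands at > 43900 nM, a limit of the assay.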